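The source may report more compounds than this note shows. Statements on the series, on what has been measured and on what is new or still open speak of the compounds shown alone.

Working notes on the series in an ADME assay on MCF7 cells (Homo sapiens) for cytotoxicity, read by MTT assay, with a stated time of 48 h; on this read-out lower numbers stand for stronger inhibition and higher numbers for weaker inhibition. Compound 1 (`Clc1ccc(-c2[nH]c3cc(Cl)ccc3c2Cn2ccnc2)cc1`) gives > 1000000 nM, which is a limit. Compound 2 (`COc1ccc(-c2[nH]c3cc(Cl)ccc3c2Cn2ccnc2)cc1`) gives > 1000000 nM, also a limit. Within the data shown here, compound 3 (`Clc1ccc(-c2[nH]c3cc(Cl)ccc3c2Cn2cncn2)cc1`) gives 382000 nM, the only actual number so far. All other readings stop at the limit of > 1000000 nM in this assay, at which 2 of the 3 values shown sit.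

Compound 4 (`COc1ccc(-c2[nH]c3cc(Cl)ccc3c2Cn2cncn2)cc1`) differs from compound 3 by methoxy in place of chloro on an aromatic carbon, with methoxy in place of chloro, para to a large group. The same exchange appears only in a step that the two limits leave unreadable from compound 1 to compound 2, so it offers no usable size. The other measured step, an at least 2.6-fold lower number from compound 1 to compound 3 (0.41 log units; beyond the scatter), is a different exchange and bears on this one only indirectly. No clear direction can be drawn, and the expected change is small: a 1.2-fold higher number from compound 3 to compound 4 (0.07 log units; within the scatter). Compound 4 is estimated at 450000 nM, with an expected range of 180000 nM to 1000000 nM.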

Compound 4, half-maximal inhibitory concentration: 14400 nM
For compound 4 the middle estimate is 31-fold (1.49 log units) above the measured one, and the stated range ends above it.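

Methoxy in place of chloro, para to a large group, now has a readable size with 1H-1,2,4-triazol-1-yl on the shared core in this assay: a 27-fold lower number from compound 3 to compound 4 (1.42 log units; beyond the scatter). With the 4-methoxyphenyl group in place, 1H-1,2,4-triazol-1-yl in place of 1H-imidazol-1-yl gives an at least 69-fold lower number from compound 2 to compound 4 (1.84 log units; beyond the scatter). Set beside the 4-chlorophenyl pair, this exchange reads: the same change on two cores in this assay, an at least 2.6-fold lower number (0.41 log units; beyond the scatter) from compound 1 to compound 3 and an at least 69-fold lower number (1.84 log units; beyond the scatter) from compound 2 to compound 4; the limit leaves it open whether they differ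

Still open, from the compounds shown here alone, is whether an amine, a hydroxyl or a longer alkoxy chain in place of methoxy would give a step of similar size.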